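Pyrazole to trimethylimidazole swap on the shared core

The compounds below may be only part of what the source reports. "The series", "measured", "known", "first", "only" and "open" are said of these compounds alone.

Measured so far:
compound 1, `Cc1nn(C)c(C)c1-c1ccc(-c2nnc(N(C)Cc3ccc4nccn4c3)o2)c(F)c1`, 3.2
compound 2, `Cc1cc(-c2c(C)n[nH]c2C)ccc1-c1nnc(N(C)Cc2ccc3nccn3c2)o1`, 3.8

In a physicochemical assay for lipophilicity, at pH 7.4 (on this read-out lower numbers stand for lower lipophilicity and higher numbers for higher lipophilicity), compound 2 stands highest of the two numbers; compound 1 sits lower by an amount beyond the usual scatter. Going by the values given here, the two differ at more than one place, so no single step is drawn between them.

Compound 3, `Cc1cc(-c2c(C)nc(C)n2C)ccc1-c1nnc(N(C)Cc2ccc3nccn3c2)o1`, is not yet measured. It differs from compound 2 by 1,2,4-trimethyl-1H-imidazol-5-yl in place of 3,5-dimethyl-1H-pyrazol-4-yl on an aromatic carbon. Among the compounds with values here, no measured pair shows this change, so the size of the step in this assay rests on judgement alone. A modest rise is expected, with an upward step a number 0.10 log units higher from compound 2 to compound 3 (within the scatter) that may or may not clear the scatter. Compound 3 is therefore estimated at 3.9 in this assay, with a range from 3.3 to 4.5.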

Compound 3, distribution coefficient: 2.6
Beside the measured number, compound 3's estimate is 1.30 log units above it, outside the stated range (below it).
By their numbers in this assay, from the lowest: compound 3; then compound 1; then compound 2.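

In this assay, this aromatic carbon, meta to a methyl group and para to a large group, proves highly sensitive to the five-membered ring it carries: 1,2,4-trimethyl-1H-imidazol-5-yl in place of 3,5-dimethyl-1H-pyrazol-4-yl gives a number 1.20 log units lower from compound 2 to compound 3 (beyond the scatter), a large step. The number falls even though the entering group has one more carbon and no hydrogen-bond donor, so for this pair, heavy-atom count does not set the direction of the change. Nothing available explains the size or direction of this step.

This single exchange does not separate the arrangement of the ring nitrogens from the change in methyl substitution. As far as these compounds go, how a morpholine or a plain phenyl at this carbon would read in this assay remains open.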